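Replacing the open chain of compound 2 with a ring

The source may report more compounds than this note shows. Statements on the series, on what has been measured and on what is new or still open speak of the compounds shown alone.

In an ADME assay on microsomes from liver (Mus musculus) for metabolic stability (on this read-out higher numbers stand for a more stable compound and lower numbers for a less stable compound), compound 1 (`C/C(CN)=C(/F)CN(C[C@H]1Cc2ccccc2CN1)[C@H]1CCCc2cccnc21`) gives 61%, and compound 2 (`C/C(=C/CN(C[C@H]1Cc2ccccc2CN1)[C@H]1CCCc2cccnc21)CN`) gives 2%, the lower of the two numbers. Compound 3 (`N[C@H]1CC[C@H](CN(C[C@H]2Cc3ccccc3CN2)[C@H]2CCCc3cccnc32)CC1`) has not been measured yet. Its difference from compound 2 lies in one group: a group of 7 heavy atoms (6 carbon, 1 nitrogen; one six-membered non-aromatic ring of carbon only) in place of a group of 5 heavy atoms (4 carbon, 1 nitrogen; no ring), on a saturated chain carbon bound to an amine nitrogen. The entering group is 4-aminocyclohexyl, on a saturated chain carbon bound to an amine nitrogen. Among the compounds with values here, only one measured step bears on this place: a number 59 percentage points lower from compound 1 to compound 2 (beyond the scatter). That large step, beyond the scatter, shows that a change here can move the number strongly. It involves no ring, however, so it is only a loose guide. Compound 2 also has little room left to fall, so a rise is expected. The expected size is a number 28 percentage points higher from compound 2 to compound 3 (beyond the scatter), although this is uncertain. For compound 3 the estimated value is 30%, with an expected range from 6% to 68%.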

Compound 3, percent of the compound remaining: 44%
Beside the measured number, compound 3's estimate is 14 percentage points below it, within the range that was stated.
By their numbers in this assay, from the lowest: compound 2; then compound 3; then compound 1.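

Swapping the open chain for 4-aminocyclohexyl gives a number 42 percentage points higher from compound 2 to compound 3 (beyond the scatter) in this assay, so the fluorine-bearing chain of compound 1 is not the only group at this place that keeps the number well clear of the bottom of the scale. The ring still does not fully match that chain, with a number 17 percentage points lower from compound 1 to compound 3 (beyond the scatter), which places it between the two open chains. No measurement shown here explains either step.

As far as these compounds go, whether the rise belongs to the carbon ring or to its amine stays open, and a plain cyclohexyl group, with no amine, would separate the two. Also open, from the compounds shown here alone, is whether the other arrangement of the two defined stereocentres of 4-aminocyclohexyl, or a fluorine on that ring, would bring the number closer to that of compound 1.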